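The source may report more compounds than this note shows. Statements on the series, on what has been measured and on what is new or still open speak of the compounds shown alone.

Measured in an ADME assay on MT4 cells (Homo sapiens) for cytotoxicity, read by MTT assay, with a stated time of 3 days; a higher number here means that more compound is tolerated, a lower number that less compound is tolerated:
- compound 1 `CC(C)(NC(=O)COC(=O)c1ccc([N+](=O)[O-])o1)c1ccccc1`: > 100000 nM (a limit, not a number)
- compound 2 `O=C(COC(=O)c1ccc([N+](=O)[O-])o1)NCC1CCCO1`: > 100000 nM (a limit, not a number)
- compound 3 `CC(C)(C)N(CCC(=O)c1ccccc1)C(=O)COC(=O)c1ccc([N+](=O)[O-])o1`: "not active" (no number reported)

Compound 3 has no single number and is reported only as "not active" (no number reported). Compound 1 and compound 2 stand at the limit of > 100000 nM in this assay, at which 2 of the 3 values shown sit.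

Compound 4 `CC(C)(C)N(Cc1ccc(F)cc1)C(=O)COC(=O)c1ccc([N+](=O)[O-])o1` is still unmeasured. The structural change is 4-fluorophenyl in place of benzoylmethyl on a saturated chain carbon bound to an amide-type nitrogen, with 4-fluorophenyl in place of benzoylmethyl on a saturated chain carbon bound to an amide-type nitrogen.

Among the compounds with values here, no measured step in this assay covers this change, and no step beyond the scatter is expected, in either direction, because compound 3 is reported as "not active" (no number reported). For compound 4 the half-maximal cytotoxic concentration is expected to be 80000 nM, with an estimated range of 25000 nM to 100000 nM.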

Compound 4, half-maximal cytotoxic concentration: > 100000 nM
Compound 4: no number, only a limit; the forecaster's own chance of this, stated with the estimate: 65%; middle value at least 1.2-fold (0.09 log units) away from the limit.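

No new step can be read between compound 3, which has no number, and compound 4, which has only a limit. The compounds shown leave open whether any structural change shifts the half-maximal cytotoxic concentration in this assay, with the values gathered as follows: the limit of > 100000 nM in this assay, at which 3 of the 4 values shown sit.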